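Reversing the amide linker in a kinase-inhibitor isothiocyanate series

The compounds below may be only part of what the source reports. "The series", "measured", "known", "first", "only" and "open" are said of these compounds alone.

Measured compounds:
compound 1 `CN(C)C(=O)c1cc2cnc(Nc3ccc(S(=O)(=O)NCCCN=C=S)cc3)nc2n1C1CCCC1` gives 58.9% in a functional assay on A549 cells (Homo sapiens) for inhibition, read by CCK-8 assay, with a stated time of 72 h, tested at 1 uM; a lower number here means a weaker effect, a higher number a stronger effect of the compound at the concentration tested
compound 2 `CN(C)C(=O)c1cc2cnc(Nc3ccc(C(=O)NCCCCCN=C=S)cc3)nc2n1C1CCCC1` gives 29.3%
compound 3 `CN(C)C(=O)c1cc2cnc(Nc3ccc(C(=O)NCCCCCN=C=S)cc3O)nc2n1C1CCCC1` gives 23.1%

Compound 2 stands second highest of the three numbers, with compound 3 nearest and within the scatter of it, and compound 1 furthest, beyond the scatter above it.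

Compound 4 `CN(C)C(=O)c1cc2cnc(Nc3ccc(NC(=O)CCCCCN=C=S)cc3)nc2n1C1CCCC1` has not been measured. It differs from compound 2 in one place: a group of 11 heavy atoms (7 carbon, 2 nitrogen, 1 oxygen, 1 sulfur; no ring) in place of a group of 11 heavy atoms (7 carbon, 2 nitrogen, 1 oxygen, 1 sulfur; no ring), on an aromatic carbon. The two compounds are built from the same atoms, joined differently, so the change is a rearrangement of the chain that carries the isothiocyanate rather than an addition or removal.

Of the measured steps, a number 29.6 percentage points lower from compound 1 to compound 2 (beyond the scatter) exchanged one chain-bearing group for another at the same position and moved the number a modest amount downward; a number 6.2 percentage points lower from compound 2 to compound 3 (within the scatter) stayed within the scatter. For the measured compounds named here, neither step rearranges the chain as the change to compound 4 does, so no measured step bears on it directly, and the data give no ground for a shift in either direction.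

Compound 4 is therefore expected to sit close to compound 2, with a number 0.7 percentage points higher from compound 2 to compound 4 (within the scatter) expected to lie within the scatter. The estimate for compound 4 is 30%, ranging from 14% to 48%.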

Compound 4, a percentage reported as inhibition, at one concentration (the size of the read-out at that concentration, not a potency): 56.1%
Compound 4: the middle estimate sits 26.1 percentage points below what was measured; the measured number lies above the stated range.
By their numbers in this assay, from the lowest: compounds 3 and 2 (each within the scatter of the next); then compounds 4 and 1 (each within the scatter of the next).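

In this assay, rearranging the chain that carries the isothiocyanate, on an aromatic carbon para to a large group, gives a number 26.8 percentage points higher from compound 2 to compound 4 (beyond the scatter). At this position, then, two groups built from the same atoms, with the same counts of hydrogen-bond donors and acceptors, are not interchangeable, and how the chain is joined to the ring matters as well as what it contains. The other new step, a number 2.8 percentage points lower from compound 1 to compound 4 (within the scatter), shows that the fall seen on replacing the chain of compound 1 with that of compound 2 does not follow from leaving the chain of compound 1 as such, and nothing measured on these compounds accounts for the difference between the two arrangements.

Going by these compounds, it remains open whether the advantage of the arrangement in compound 4 would survive a longer chain, or the replacement of the isothiocyanate by an acrylamide or a primary amine. Also open, on these data alone, is how hydroxy on the aromatic ring of compound 4 would act, given that the same addition gave a number 6.2 percentage points lower from compound 2 to compound 3 (within the scatter).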